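The compounds below may be only part of what the source reports. "The series", "measured", "known", "first", "only" and "open" are said of these compounds alone.

Measured in a functional assay on L1210 cells (Mus musculus) for inhibition; on this read-out higher numbers stand for weaker inhibition and lower numbers for stronger inhibition:
- Compound 1 `C#CCN(Cc1ccc2nc(NCC(=O)O)nc(O)c2c1)c1ccc(C(=O)NC(CCC(=O)O)C(=O)O)cc1`: > 100000 nM, a limit
- Compound 2 `C#CCN(Cc1ccc2nc(-n3ccnc3)nc(O)c2c1)c1ccc(C(=O)NC(CCC(=O)O)C(=O)O)cc1`: > 100000 nM, a limit
- Compound 3 `COc1nc(O)c2cc(CNc3ccc(C(=O)NC(CCC(=O)O)C(=O)O)cc3)ccc2n1`: 6400 nM

Among the measured compounds shown here, the first two values are limits of the assay, not numbers, so compound 3 holds the only true number here. Compound 4 `COc1nc(O)c2cc(CN(CCCO)c3ccc(C(=O)NC(CCC(=O)O)C(=O)O)cc3)ccc2n1`, not yet measured, differs from compound 3 by one change: 3-hydroxypropyl in place of hydrogen on a nitrogen on an aromatic ring. In words, 3-hydroxypropyl replaces hydrogen on a nitrogen on an aromatic ring. For the measured compounds named here, the only measured step, a step that the two limits leave unreadable from compound 1 to compound 2, has no readable size and lies at another place, so it offers no guide. The expectation therefore rests on compound 3 at 6400 nM, with no shift beyond the scatter expected: the estimated change is a 1.3-fold higher number from compound 3 to compound 4 (0.10 log units; within the scatter). Compound 4 is expected at 8000 nM, with an estimated range of 2000 nM to 40000 nM.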

Compound 4, half-maximal inhibitory concentration: 80000 nM
Compound 4: middle estimate off by 10-fold (1.00 log units), on the low side; the whole stated range lies below it.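

In this assay, the nitrogen on an aromatic ring proves sensitive to substitution: 3-hydroxypropyl in place of hydrogen gives a 13-fold higher number from compound 3 to compound 4 (1.10 log units; beyond the scatter), meaning weaker inhibition. Among the compounds shown here, this is the first readable step in the set, and the first to speak to this position, as the only earlier step cannot be read and lies elsewhere. Compound 4 still gives a true number, while compound 1 and compound 2 give only a limit: the limit of > 100000 nM in this assay, at which 2 of the 4 values shown sit.

The compounds shown leave open whether the chain itself or its hydroxyl goes with the change. A small methyl, a plain propyl or a chain ending in an amine on this nitrogen would help separate these.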